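From Cyclopropylmethyl to Cyclobutyl on the Aromatic Nitrogen

A few compounds are considered here, and "the series" means these few. Any claim that something is new, unique, unknown or untested is made for them only; others in the source may bear on it.

Measured so far in an assay on HEK293 cells for positive allosteric modulation of metabotropic glutamate receptor 2 (Rattus norvegicus), read by thallium flux; a higher number here means that more compound is needed for the effect, a lower number that less compound is needed:
- compound 1, `O=C1c2ccc(OCc3cccc(-c4ccc(Cl)cc4F)c3)cc2CN1C1CCCC1`, gives > 5000 nM, which is a limit of the assay and not a number.
- compound 2, `Cn1sc2cc(OCc3cccc(-c4ccc(Cl)c(C(=O)O)c4)c3)ccc2c1=O`, gives 640 nM.
- compound 3, `O=C(O)c1cc(-c2cccc(COc3ccc4c(=O)n(CC5CC5)sc4c3)c2)ccc1Cl`, gives 2480 nM.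

Compound 3 thus holds the highest of the two numbers; the nearest value is that of compound 2, and the gap is a 3.9-fold higher number from compound 2 to compound 3 (0.59 log units; beyond the scatter), a change beyond the scatter brought by a cyclopropyl in place of hydrogen on the saturated chain carbon bound to the aromatic nitrogen. Compound 1 sits at the limit of > 5000 nM in this assay, at which 1 of the 3 values shown sits.

Compound 4, `O=C(O)c1cc(-c2cccc(COc3ccc4c(=O)n(C5CCC5)sc4c3)c2)ccc1Cl`, differs from compound 3 by cyclobutyl in place of cyclopropylmethyl on an aromatic nitrogen. Among the measured compounds shown here, no measured step swaps one small ring for another in this way; the only nearby step, the addition of the cyclopropyl from compound 2 to compound 3, moved the number modestly. With the same atoms merely rejoined, compound 4 is expected to stay near compound 3, at a step of a 1.0-fold higher number from compound 3 to compound 4 (0.00 log units; within the scatter), within the scatter. The estimate for compound 4 in this assay is therefore 2500 nM, with a range from 800 nM to 8000 nM.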

Compound 4, half-maximal effective concentration: 580 nM
The estimate for compound 4 lay 4.3-fold (0.63 log units) above the measured number, and the stated range ends above it.
By their numbers in this assay, from the lowest: compounds 4 and 2 (each within the scatter of the next); then compound 3. At a limit, above all of these: compound 1.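

In this assay, cyclopropylmethyl and cyclobutyl carry the same count of carbon atoms, yet on this aromatic nitrogen next to the ring sulfur the swap gives a 4.3-fold lower number from compound 3 to compound 4 (0.63 log units; beyond the scatter), so how those carbons are joined matters and not only how many there are. Set against methyl, cyclobutyl gives a 1.1-fold lower number from compound 2 to compound 4 (0.04 log units; within the scatter), so the rise seen earlier with cyclopropylmethyl, a 3.9-fold higher number from compound 2 to compound 3 (0.59 log units; beyond the scatter), does not follow from the number of carbons on this nitrogen alone. Nothing measured here explains why the two rings differ.

The compounds shown leave open how a straight butyl chain or a chain ending in an amine would behave on this nitrogen. They also leave open whether the gap between the two rings persists when a tetrazole replaces the carboxylic acid.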